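Longer Acyl Chain, Lower Tolerated Dose?

The compounds below may be only part of what the source reports. "The series", "measured", "known", "first", "only" and "open" are said of these compounds alone.

Values in a functional assay on CCRF-CEM cells (Homo sapiens) for cytotoxicity; a higher number here means that more compound is tolerated, a lower number that less compound is tolerated:
- Compound 1 `CCCC(=O)Nc1nc(N)nc2c1ncn2[C@H]1CO[C@@H](CO)O1`: > 100000 nM (a limit)
- Compound 2 `CCCCCCCCCC(=O)Nc1nc(N)nc2c1ncn2[C@H]1CO[C@@H](CO)O1`: 65000 nM
- Compound 3 `CCCCCCCCCCCCCCCC(=O)Nc1nc(N)nc2c1ncn2[C@H]1CO[C@@H](CO)O1`: not yet measured

Among the measured compounds shown here, compound 2 at 65000 nM holds the only actual number so far. Compound 1 stands at > 100000 nM, which is a limit. The move to compound 3 is hexyl in place of hydrogen on a saturated chain carbon, nine bonds along the chain from a carbonyl carbon, which extends the chain further. For the measured compounds named here, the one measured step that bears on this is the same kind of extension, an at least 1.5-fold lower number from compound 1 to compound 2 (0.18 log units; that floor lies within the scatter), and its floor lies within the scatter. This gives weak guidance, but a modest further fall in the number is expected. The expected change is a 2.2-fold lower number from compound 2 to compound 3 (0.34 log units; beyond the scatter). For compound 3 the estimated value is 30000 nM, with an expected range of 8000 nM to 100000 nM.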

Compound 3, half-maximal cytotoxic concentration: > 100000 nM
Compound 3: no number, only a limit; the forecaster's own chance of this, stated with the estimate: 20%; middle value at least 3.3-fold (0.52 log units) from the limit.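

Extending the chain further in this assay does not continue the earlier drop, giving an at least 1.5-fold higher number from compound 2 to compound 3 (0.18 log units; that floor lies within the scatter). This floor leaves the rise unconfirmed, but the new result gives no sign that each added stretch of chain lowers the number, so chain length shows no steady trend across these compounds. Compound 1 and compound 3 both stop at a limit of the assay, leaving compound 2 with the only actual number: the limit of > 100000 nM in this assay, at which 2 of the 3 values shown sit.

Going by these compounds, whether an intermediate chain length would give a lower number remains open. So does the effect of ending the chain in an amine or a carboxylic acid.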